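Adding an ethylsulfonylamino-bearing Arm to Compound 2

A few compounds are considered here, and "the series" means these few. Any claim that something is new, unique, unknown or untested is made for them only; others in the source may bear on it.

compound 1 `CCS(=O)(=O)N1CCC(c2cncc(N3C(=O)c4ccc(Cl)cc4C3(C)C)c2)CC1`: 3 nM
compound 2 `CC1(C)c2cc(Cl)ccc2C(=O)N1c1cccnc1`: 108 nM
compound 3 `CC1c2cc(Cl)ccc2C(=O)N1c1cccnc1`: 123 nM

In an assay on cells for inhibition of cytochrome P450 11B2, mitochondrial (Homo sapiens), read by HTRF (on this read-out higher numbers stand for weaker inhibition and lower numbers for stronger inhibition), compound 2 stands second highest of the three numbers; compound 3 lies within the scatter of it, while compound 1 gives a far lower number. Among the measured compounds shown here, the only measured step, a 1.1-fold higher number from compound 2 to compound 3 (0.06 log units; within the scatter), changes a saturated ring carbon and does not touch the aromatic ring, so it says little about the change at hand. Compound 4 `CCS(=O)(=O)NCc1cncc(N2C(=O)c3ccc(Cl)cc3C2(C)C)c1` carries ((ethylsulfonyl)amino)methyl in place of hydrogen on an aromatic carbon. For the measured compounds named here, no step covers this change directly; compound 1 alone shows that a larger group carrying an ethylsulfonyl at that place goes with a much lower number than compound 2. Compound 4 is therefore expected to show a lower number, a 7.2-fold lower number from compound 2 to compound 4 (0.86 log units; beyond the scatter), estimated at 15 nM with a range of 3 nM to 70 nM.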

Compound 4, half-maximal inhibitory concentration: 92 nM
Compound 4: middle estimate off by 6.1-fold (0.79 log units), on the low side, and the stated range ends below it.
By their numbers in this assay, from the lowest: compound 1; then compounds 4, 2 and 3 (each within the scatter of the next).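

In this assay, ((ethylsulfonyl)amino)methyl in place of hydrogen on this aromatic carbon gives a 1.2-fold lower number from compound 2 to compound 4 (0.07 log units; within the scatter), so an ethylsulfonyl group at this place does not by itself go with a much lower number. Compound 1 gives 3 nM and compound 4 gives 92 nM, which ties the low number to the whole larger group of compound 1 and not to the ethylsulfonyl alone. No measurement shown explains this difference. The compounds shown leave open how a longer chain carrying the ethylsulfonyl, or a plain amine, would read at this place.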